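Replacing Trifluoromethyl with Methyl on a Shared Core

The source may hold more compounds than are shown below. What is called first, only, known or untested is meant among the compounds shown, and "the series" means these compounds.

Of the compounds shown here, two have been measured so far in an assay on Jurkat cells for inhibition of nuclear factor NF-kappa-B complex (Homo sapiens), read by a luciferase reporter; on this read-out higher numbers stand for weaker inhibition and lower numbers for stronger inhibition. Compound 1 `Cc1nc(Cl)ncc1C(=O)Nc1cc(Cl)cc(Cl)c1` gives 500 nM in this assay. Compound 2 `O=C(Nc1ccc(C(F)(F)F)cc1C(F)(F)F)c1cc(C(F)(F)F)nc(Cl)n1` is reported only as a limit of this assay, > 10000 nM, so no number is known for it; this is the limit of > 10000 nM in this assay, at which 1 of the 2 values shown sits. Compounds 1 and 2 differ in more than one place, so nothing can be said about any single change between them beyond what their two values show.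

Compound 3 `Cc1cc(C(=O)Nc2ccc(C(F)(F)F)cc2C(F)(F)F)nc(Cl)n1` has not yet been measured in this assay. It differs from compound 2 in one place: methyl in place of trifluoromethyl on an aromatic carbon. Compound 1 also carries a methyl at that position of the shared core, but its other part differs from that of compound 3, so it offers no direct guide.

Since compound 2 sits at a limit, the step from compound 2 to compound 3 cannot be measured exactly, and the expectation here is an at least 1.2-fold lower number from compound 2 to compound 3 (0.09 log units; that floor lies within the scatter), a modest gain at most. Compound 3 is therefore estimated at 8000 nM, within a range from 1500 nM to 30000 nM.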

Compound 3, half-maximal inhibitory concentration: > 10000 nM
Compound 3: a limit, no number; the forecaster's own chance of this, stated with the estimate: 50%; at least 1.2-fold (0.09 log units) between middle value and limit.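

In this assay compound 3 gives > 10000 nM, which is a limit and not a number. Compound 2 is reported as a limit too, so no step can be read between compound 2 and compound 3: the limit of > 10000 nM in this assay, at which 2 of the 3 values shown sit.

The compounds shown leave open whether methyl in place of trifluoromethyl on an aromatic carbon changes inhibition at all.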